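Working notes: nitro in place of propoxy, compound 3

The source may hold more compounds than are shown below. What is called first, only, known or untested is meant among the compounds shown, and "the series" means these compounds.

Compound 2 `CCCOc1ccc(C(=O)/C=C/c2ccc(C(=O)Nc3cccc(-c4cc(C(=O)OC)no4)c3)cc2)cc1` stands only at a limit in an ADME assay on Vero cells (Chlorocebus sabaeus) for cytotoxicity, read by MTT assay, with a stated time of 72 h; a higher number here means that more compound is tolerated, a lower number that less compound is tolerated. In this assay compound 2 reads > 40 ug/mL, which is a limit of the assay and not a number. Compound 1 `COC(=O)c1cc(-c2cccc(NC(=O)c3ccc(/C=C/C(=O)c4cccc(OC)c4)cc3)c2)on1` likewise reads > 100 ug/mL in this assay, again a limit. Within the data shown here, the one measured step, a step that the two limits leave unreadable from compound 1 to compound 2, is accordingly unreadable; the limit of > 100 ug/mL in this assay, at which 1 of the 2 values shown sits, and the limit of > 40 ug/mL in this assay, at which 1 of the 2 values shown sits, are all that is known. Compound 3 `COC(=O)c1cc(-c2cccc(NC(=O)c3ccc(/C=C/C(=O)c4ccc([N+](=O)[O-])cc4)cc3)c2)on1` differs from compound 2 by nitro in place of propoxy on an aromatic carbon. Among the measured compounds shown here, no measured step bears on this change, so no movement beyond the scatter is expected, and a further limit seems likely. Compound 3 is estimated at 80 ug/mL (30 ug/mL to 150 ug/mL), with a step that the limit leaves unreadable from compound 2 to compound 3 expected.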

Compound 3, half-maximal cytotoxic concentration: > 20 ug/mL
Compound 3 gave a limit, no number; the forecaster's own chance of this, stated with the estimate: 70%; the middle value does not contradict the limit.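

In this assay compound 3 reads > 20 ug/mL, a limit of the assay and not a number. Among these compounds, no step among compound 1, compound 2 and compound 3 can be read. The compounds shown leave open whether nitro in place of propoxy moves the value at all.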